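The source may report more compounds than this note shows. Statements on the series, on what has been measured and on what is new or still open speak of the compounds shown alone.

Compound 1 `O=C(Nc1ccc(Oc2ccnc3[nH]ccc23)cc1)c1nn(-c2ccc(Cl)cc2)ccc1=O`: 10600 nM
Compound 2 `O=C(Nc1ccc(Oc2ccnc3[nH]ccc23)c(F)c1)c1nn(-c2ccc(Cl)c(C(F)(F)F)c2)ccc1=O`: 11600 nM
Compound 3 `Cn1ccc2c(Oc3ccc(NC(=O)c4nn(-c5ccc(Cl)cc5)ccc4=O)cc3)ccnc21`: > 60000 nM

Of the compounds shown here, three on a shared core have been tested in a functional assay on MCF7 cells (Homo sapiens) for cytotoxicity, read by MTT assay, with a stated time of 72 h; a higher number here means a weaker inhibitor, a lower number a stronger inhibitor. Compound 1 gives 10600 nM, and compound 2 gives 11600 nM; these two values lie within the usual scatter of each other. Within the data shown here, compound 2 differs from compound 1 in two places at once, so no single step can be drawn between them. For compound 3 this assay reports only a limit, > 60000 nM, not a number. The change from compound 1 to compound 3 is a methyl in place of hydrogen on an aromatic nitrogen, and it reads as an at least 5.6-fold higher number from compound 1 to compound 3 (0.75 log units; beyond the scatter); its true size is known only through (the limit of > 60000 nM in this assay, at which 1 of the 3 values shown sits).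

Compound 4 `Cn1ccc2c(Oc3ccc(NC(=O)c4nn(-c5ccc(Cl)c(C(F)(F)F)c5)ccc4=O)cc3)ccnc21` has not yet been measured. It differs from compound 3 by trifluoromethyl in place of hydrogen on an aromatic carbon. Among the measured compounds shown here, no measured step covers this change by itself; the only guide is that compound 1 and compound 2, which share this difference alongside a second one, sit within the scatter of each other. The expected step is therefore a step that the limit leaves unreadable from compound 3 to compound 4, small or none beyond the scatter. Compound 4 is expected to give about 80000 nM, within 30000 nM to 250000 nM, most likely again as a limit of this assay.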

Compound 4, half-maximal inhibitory concentration: 15200 nM
Beside the measured number, compound 4's estimate is 5.3-fold (0.72 log units) above it; measured number below the stated range.
By their numbers in this assay, from the lowest: compounds 1, 2 and 4 (each within the scatter of the next). At a limit, above all of these: compound 3.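

In this assay, trifluoromethyl on this aromatic carbon of the 4-chlorophenyl ring gives a clear change by itself: an at least 3.9-fold lower number from compound 3 to compound 4 (0.59 log units; beyond the scatter). Compound 1 and compound 2 could not show this, as they differ in two places at once, so their closeness said nothing about this group alone. The exact size of the new step cannot be read because the value of compound 3, > 60000 nM, is a limit of the assay and not a number: the limit of > 60000 nM in this assay, at which 1 of the 4 values shown sits.

The compounds shown leave open whether the same change would move the number on the core of compound 1, where the aromatic nitrogen carries hydrogen rather than methyl. They also leave open whether a nitrile, an amine or a plain methyl at this place would give a similar step.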